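Methoxy to hydroxy on the amide side chain

The source may hold more compounds than are shown below. What is called first, only, known or untested is meant among the compounds shown, and "the series" means these compounds.

Of the compounds shown here, two carry numbers so far. Compound 1 `COCCNC(=O)c1cc2cccc(OC)c2oc1=N` gives 43% in an assay on HEK293 cells for displacement of a labelled ligand from adenosine receptor A2b (Homo sapiens), read by scintillation counting, with a stated time of 30 min, tested at 10 uM (a lower number here means less inhibition, a higher number more inhibition at the concentration tested (going by the name of the read-out)), the higher of the two, while compound 2 `O=C(NC1CCCC1)c1cc2ccccc2oc1=O` gives 18% in this assay, a gap beyond the scatter; the two share no single-site difference, so only their values stand. Compound 3 `COc1cccc2cc(C(=O)NCCO)c(=N)oc12` differs from compound 1 by hydrogen in place of methyl on an oxygen on a saturated carbon, that is, 2-methoxyethyl to 2-hydroxyethyl. Among the compounds with values here, no step of this kind has been measured; a change in this assay not beyond the scatter, if anything slightly lower, is expected. Compound 3 is expected at 38%, with a range from 20% to 55%. The expected step is a number 5 percentage points lower from compound 1 to compound 3 (within the scatter).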

Compound 3, a percentage reported as inhibition, at one concentration (the size of the read-out at that concentration, not a potency): 65%
Estimate against measurement, compound 3: 27 percentage points below; the whole stated range lies below it.
By their numbers in this assay, from the lowest: compound 2; then compound 1; then compound 3.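

In this assay, within the data shown here, the change from 2-methoxyethyl to 2-hydroxyethyl reads as a number 22 percentage points higher from compound 1 to compound 3 (beyond the scatter) and is the first single-site step. The amide side chain therefore responds to hydrogen in place of methyl on this oxygen, with the shared core held constant. Nothing available accounts for the direction or size of this step.

Going by these compounds, whether the hydroxy group itself is what counts remains open, as a 2-aminoethyl side chain or a longer 3-hydroxypropyl chain would show. This single pair also leaves open whether the step carries over to other cores.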